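Moving the hydroxyl and dropping the methoxy group

The source may report more compounds than this note shows. Statements on the series, on what has been measured and on what is new or still open speak of the compounds shown alone.

Compound 1 `COc1cc(/C=N/NC(=O)CCN2CCN(c3ccnc4cc(Cl)ccc34)CC2)ccc1O` carries a 4-hydroxy-3-methoxyphenyl group on a carbon with a double bond to nitrogen. In a physicochemical assay for inhibition, read by spectrophotometry, with a stated time of 24 h, tested at 2.5 mM (a lower number here means less inhibition, a higher number more inhibition at the concentration tested (going by the name of the read-out)), compound 1 gives 50.7%, the highest of the three measured numbers. Compound 2 `COc1cc(/C=N/NC(=O)CCN2CCN(c3ccnc4cc(Cl)ccc34)CC2)ccc1OC(C)C`, which differs only by an isopropyl in place of hydrogen on an oxygen on an aromatic ring, gives 15.7% in this assay. Compound 3 `NNC(=O)CCN1CCN(c2ccnc3cc(Cl)ccc23)CC1`, in which the larger group on an amide-type nitrogen is replaced by one nitrogen atom, gives 21.7%. Both steps away from compound 1 go down: a number 35 percentage points lower from compound 1 to compound 2 (beyond the scatter) and a number 29 percentage points lower from compound 1 to compound 3 (beyond the scatter).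

Compound 4 `O=C(CCN1CCN(c2ccnc3cc(Cl)ccc23)CC1)N/N=C/c1ccccc1O` has not yet been measured. Its change from compound 1 is 2-hydroxyphenyl in place of 4-hydroxy-3-methoxyphenyl on a carbon with a double bond to nitrogen. For the measured compounds named here, no measured step matches this exactly. The step to compound 2 shows that a change at the hydroxyl on that ring already moved the number a great deal, and the step to compound 3 shows that removing the whole aromatic piece also lowered it. Compound 4 keeps a ring with a hydroxyl but loses the methoxy group and carries the hydroxyl in a different place, so a drop beyond the scatter is expected, though smaller than either measured step. For compound 4 the estimate in this assay is 35%, within 15% to 55%, meaning an expected step of a number 15.7 percentage points lower from compound 1 to compound 4 (beyond the scatter).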

Compound 4, a percentage reported as inhibition, at one concentration (the size of the read-out at that concentration, not a potency): 83.2%
Compound 4: middle estimate off by 48.2 percentage points, on the low side, and the stated range ends below it.
By their numbers in this assay, from the lowest: compounds 2 and 3 (each within the scatter of the next); then compound 1; then compound 4.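

In this assay the group on the carbon with a double bond to nitrogen can raise the number as well as lower it: 2-hydroxyphenyl in place of 4-hydroxy-3-methoxyphenyl gives a number 32.5 percentage points higher from compound 1 to compound 4 (beyond the scatter), whereas both earlier steps away from compound 1 went down. Adding the aromatic piece to the shorter end gives a number 61.5 percentage points higher from compound 3 to compound 4 (beyond the scatter), and the gap from the 4-isopropoxy-3-methoxyphenyl group is wider still, with a number 67.5 percentage points higher from compound 2 to compound 4 (beyond the scatter), which shows how much the outcome depends on what the aromatic ring carries. No measurement here explains why 2-hydroxyphenyl gives the higher number.

This change does two things at once, removing the methoxy group and placing the hydroxyl differently on the ring, and the compounds shown leave open which of the two accounts for the rise. Also open, on these data alone, is whether a 2-aminophenyl group, with an amine where the hydroxyl stands, would hold the number as high as 2-hydroxyphenyl does.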